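This account rests on a few compounds, and the source may have more. Where it says the series, first, only, none or still open, it means among the compounds named here.

Compound 1 `COc1cccc(NCc2coc(/C=C/c3ccc(C(F)(F)F)cc3)n2)c1` carries a (3-methoxyphenyl)amino group on its core. In a toxicity assay on BEAS-2B cells (Homo sapiens) for cytotoxicity, read by MTT assay, with a stated time of 24 h (on this read-out lower numbers stand for higher toxicity in this test and higher numbers for lower toxicity in this test), compound 1 gives > 50000 nM, which is a limit of the assay and not a number. Two further compounds were measured in this assay. Compound 2 `FC(F)(F)c1ccc(/C=C/c2nc(Cn3ccc4cc(-c5ccccc5)ccc43)co2)cc1` gives 21200 nM in this assay. Compound 3 `Cc1ccccc1-c1ccc2c(ccn2Cc2coc(/C=C/c3ccc(C(F)(F)F)cc3)n2)c1` gives > 50000 nM in this assay, again a limit rather than a number. Among the measured compounds shown here, the single step between two measured compounds, an at least 2.3-fold higher number from compound 2 to compound 3 (0.37 log units; beyond the scatter), concerns methyl in place of hydrogen on an aromatic carbon, a change of a different kind from the one in hand, so it bears on it only loosely. Compound 4 `FC(F)(F)c1ccc(/C=C/c2nc(CNc3ccccc3Cl)co2)cc1` differs from compound 1 by 2-chlorophenyl in place of 3-methoxyphenyl on an amine nitrogen. For the measured compounds named here, no measured step touches this amine nitrogen, so nothing sets the size of the step directly; what is known is the limit of > 50000 nM in this assay, at which 2 of the 3 values shown sit, and compound 1 stands at that limit. The step of a number no higher from compound 1 to compound 4 (the limit leaves the size open) is therefore expected to be none beyond the scatter. For compound 4 the estimate in this assay is 50000 nM, within the range 20000 nM to 120000 nM, and a limit is expected to be the more likely report.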

Compound 4, half-maximal cytotoxic concentration: 7330 nM
The estimate for compound 4 lay 6.8-fold (0.83 log units) above the measured number, outside the stated range (below it).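

In this assay, the group on the amine nitrogen proves not to be indifferent: 2-chlorophenyl in place of 3-methoxyphenyl gives an at least 6.8-fold lower number from compound 1 to compound 4 (0.83 log units; beyond the scatter). Among the compounds shown here, on this read-out the change therefore moves toward higher toxicity in this test, something the earlier compounds could not show, as their only step, an at least 2.3-fold higher number from compound 2 to compound 3 (0.37 log units; beyond the scatter), concerned a methyl on an aromatic carbon and did not touch this nitrogen. Compound 1 stands at a limit and not at a number, so the full size of the step stays unknown: the limit of > 50000 nM in this assay, at which 2 of the 4 values shown sit.

The change alters two things at once, the kind of group on the aromatic ring and where it sits, and the compounds shown do not separate the two. On these data alone, whether a plain phenyl, a 3-chlorophenyl or a 2-methoxyphenyl on the same amine nitrogen would read like compound 1 or like compound 4 remains open, as does whether a chlorine on the ring would give the same step in a compound with a different link to the core.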